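Methyl in Place of Chloro: an Expected Cytotoxicity

A few compounds are considered here, and "the series" means these few. Any claim that something is new, unique, unknown or untested is made for them only; others in the source may bear on it.

Measured so far:
compound 1 `Cc1ccccc1NC(=O)CSc1nccn1-c1ccc(Cl)cc1` gives 160000 nM in an ADME assay on MT4 cells (Homo sapiens) for cytotoxicity, read by MTT assay; on this read-out lower numbers stand for higher toxicity in this test and higher numbers for lower toxicity in this test.
compound 2 `O=C(CSc1nccn1-c1ccc(Cl)cc1)Nc1ccccc1Cl` gives > 330000 nM in this assay; this is a limit of the assay, not a number.

Among the measured compounds shown here, compound 1 holds the only plain number in this assay, while compound 2 sits at the limit (the limit of > 330000 nM in this assay, at which 1 of the 2 values shown sits). For the measured compounds named here, the single measured step, an at least 2.0-fold higher number from compound 1 to compound 2 (0.31 log units; beyond the scatter), is the chloro in place of methyl swap on the ring next to the amide, and it moved the number beyond the scatter.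

Compound 3 `Cc1ccc(-n2ccnc2SCC(=O)Nc2ccccc2C)cc1` is not yet measured. It differs from compound 1 by methyl in place of chloro on an aromatic carbon. Going by the values given here, this change sits on the other six-membered aromatic ring of carbon only, the one bearing the large group, and runs in the reverse sense from the measured swap, so no measured step bears on it directly. Without a directly relevant comparison, the expectation is no change beyond the scatter in this assay.

Compound 3 is therefore estimated at 160000 nM, with a range from 60000 nM to 400000 nM, meaning an expected step of no change at the digits printed from compound 1 to compound 3 (within the scatter).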

Compound 3, half-maximal cytotoxic concentration: 147000 nM
Compound 3: the middle estimate sits 1.1-fold (0.04 log units) above what was measured; low and high end bracket the measured number.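

In this assay the exchange of 4-chlorophenyl for 4-methylphenyl gives a 1.1-fold lower number from compound 1 to compound 3 (0.04 log units; within the scatter) and so leaves the two compounds indistinguishable in this test, which shows that, at this place para to a large group, chloro and methyl read alike. Among the compounds shown here, the one earlier step shows an at least 2.0-fold higher number from compound 1 to compound 2 (0.31 log units; beyond the scatter) for a swap between the same two groups on the other six-membered aromatic ring, so in these three compounds the exchange registers on that ring and not on this one. As far as these compounds go, compound 2 gives > 330000 nM as a limit of the assay and not as a number, so the full size of that earlier step stays unknown.

For the compounds shown here, still open is whether this position would stay as quiet in this assay with a quite different group there, such as an amine, a carboxylic acid or a longer chain, since chloro and methyl are the only two groups seen at it so far. Nothing measured here offers a cause for why the two rings respond differently.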